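Solubility step from compound 1 to compound 4

The source may hold more compounds than are shown below. What is called first, only, known or untested is meant among the compounds shown, and "the series" means these compounds.

Compound 1, `Cc1cc(-c2cnc(NCc3c(F)ccc4c3CCO4)c3cn[nH]c(=O)c23)n(C)n1`: 1000 nM
Compound 2, `O=C1CCCN1c1cnc(NCc2c(F)ccc3c2CCO3)n2cnnc12`: 640000 nM
Compound 3, `Cc1ncccc1-c1cnc(NCc2c(F)ccc3c2CCO3)c2n[nH]c(=O)n12`: < 2000 nM

In a physicochemical assay for solubility, read by LC-MS, in phosphate buffer, with a stated time of 24 h, at pH 7.4 (on this read-out lower numbers stand for lower solubility and higher numbers for higher solubility), compound 1 gives 1000 nM, the lowest of the two numbers measured. Compound 2 gives 640000 nM, a gap far beyond the scatter. For compound 3 the result is only a limit of the assay, (the limit of < 2000 nM in this assay, at which 1 of the 3 values shown sits).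

Compound 4, `CNC(=O)c1ncc(-c2cnc(NCc3c(F)ccc4c3CCO4)c3cn[nH]c(=O)c23)n1C`, has not yet been measured in this assay. It differs from compound 1 in one place: 1-methyl-2-(methylcarbamoyl)-1H-imidazol-5-yl in place of 1,3-dimethyl-1H-pyrazol-5-yl on an aromatic carbon. Going by the values given here, no pair of measured compounds here shares the core of compound 1 while differing in only one place, so the size of this step cannot be read from the numbers already in hand. The step from compound 1 to compound 4 in this assay is expected to be an increase beyond the scatter, a 10-fold higher number from compound 1 to compound 4 (1.00 log units; beyond the scatter). Compound 4 is therefore estimated to give 10000 nM in this assay, within a range from 2000 nM to 60000 nM.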

Compound 4, solubility: 5000 nM
Estimate against measurement, compound 4: 2.0-fold (0.30 log units) above; the measured number falls inside the stated range.
By their numbers in this assay, from the lowest: compound 1; then compound 4; then compound 2.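

Going by these compounds alone, the step gives the first reading of a change at this position on the core of compound 1: in this assay, 1-methyl-2-(methylcarbamoyl)-1H-imidazol-5-yl in place of 1,3-dimethyl-1H-pyrazol-5-yl brings a 5.0-fold higher number from compound 1 to compound 4 (0.70 log units; beyond the scatter), a modest change. It shows that the read-out responds to the group on this aromatic carbon, para to a large group, and that the entering group, unlike the one it replaces, carries a hydrogen-bond donor and a carbonyl. Nothing measured here accounts for the size of this step.

A single step cannot separate the contribution of the methylcarbamoyl group from that of the ring carrying it. The compounds shown also leave open what an amine or a carboxylic acid in place of the methylcarbamoyl group would do at this position.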